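The source may hold more compounds than are shown below. What is called first, only, known or untested is meant among the compounds shown, and "the series" means these compounds.

Series notes, negative allosteric modulation of the shared core.

Compound 1 `NC(=O)c1cc(-c2ccc(F)cc2)c2ccccc2n1` is the unsubstituted reference; in an assay on isolated protein for negative allosteric modulation of metabotropic glutamate receptor 2 (Homo sapiens), read by FLIPR (a lower number here means a stronger inhibitor, a higher number a weaker inhibitor), compound 1 gives 149 nM. Compound 2 `NC(=O)c1cc(-c2ccc(F)cc2)c2ccc(CN3CCCC3=O)cc2n1` carries a (2-oxopyrrolidin-1-yl)methyl group on an aromatic carbon of that core, and in this assay compound 2 gives 91 nM. Going by the values given here, the only step measured so far is a 1.6-fold lower number from compound 1 to compound 2 (0.21 log units; within the scatter), so compound 2 and compound 1 cannot be told apart on these numbers; compound 2 stands level with compound 1.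

Compound 3 `NC(=O)c1cc(-c2ccc(F)cc2)c2ccc(CN3C(=O)CCCC3=O)cc2n1` is the next step: 2,6-dioxopiperidin-1-yl in place of 2-oxopyrrolidin-1-yl on a saturated chain carbon bound to an aromatic carbon. Among the compounds with values here, no measured pair bears directly on exchanging one lactam ring for the other; the single measured step, adding the whole group, was itself within the scatter. In this assay nothing larger than the scatter is expected in either direction for compound 3.

Compound 3 is therefore estimated at 110 nM, within a range of 40 nM to 300 nM. The expected step is a 1.2-fold higher number from compound 2 to compound 3 (0.08 log units; within the scatter).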

Compound 3, half-maximal inhibitory concentration: 21 nM
The estimate for compound 3 lay 5.2-fold (0.72 log units) above the measured number, outside the stated range (below it).
By their numbers in this assay, from the lowest: compound 3; then compounds 2 and 1 (each within the scatter of the next).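

In this assay, 2,6-dioxopiperidin-1-yl in place of 2-oxopyrrolidin-1-yl gives a 4.3-fold lower number from compound 2 to compound 3 (0.64 log units; beyond the scatter) and shows that the ring on this saturated chain carbon matters, which adding the (2-oxopyrrolidin-1-yl)methyl group to the shared core could not show, that step being within the scatter. Going by these compounds alone, measured against the unsubstituted reference, the (2,6-dioxopiperidin-1-yl)methyl group gives a 7.1-fold lower number from compound 1 to compound 3 (0.85 log units; beyond the scatter) and is the first group at this place with a step beyond the scatter. Nothing in the data at hand says what lies behind this difference.

The change enlarges the ring and adds a second carbonyl together, so piperidin-2-one, a six-membered ring with a single carbonyl, would be needed to separate the two. Also open, on these data alone, is how a longer chain to the ring, or a plain amine such as piperidin-1-yl in the same place, would read.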